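This account rests on a few compounds, and the source may have more. Where it says the series, first, only, none or still open, it means among the compounds named here.

Working notes on the series. For the measured compounds named here, compound 1 `O=C(/C=C/C1(O)C=CC(O)CC1=O)OC[C@H]1O[C@@H](Oc2ccc(O)cc2)[C@H](O)[C@@H](O)[C@@H]1O` and compound 2 `O=C1C=CC(O)(/C=C/C(=O)OC[C@H]2O[C@@H](Oc3ccc(O)cc3)[C@H](OC(=O)/C=C/CC3(O)C=CC(=O)C=C3)[C@@H](O)[C@@H]2O)C=C1` are the two measured members. In an ADME assay on HepG2 cells (Homo sapiens) for cytotoxicity, read by resazurin assay, with a stated time of 72 h (on this read-out higher numbers stand for weaker inhibition and lower numbers for stronger inhibition), compound 1 gives > 690000 nM, which is a limit of the assay and not a number, so compound 1 sits at the limit of > 690000 nM in this assay, at which 1 of the 2 values shown sits, and its position is open on the weak side. In this assay compound 2 gives 340000 nM, an actual number. Going by the values given here, no step between the two measured compounds is recorded, so no measured step size is available for guidance. Compound 3 `O=C1C=CC(O)(/C=C/C(=O)OC[C@H]2O[C@@H](Oc3ccc(O)cc3)[C@H](O)[C@@H](O)[C@@H]2O)C=C1` is not yet measured. It differs from compound 1 by a group of 8 heavy atoms (6 carbon, 2 oxygen; one six-membered non-aromatic ring of carbon only) in place of a group of 9 heavy atoms (6 carbon, 3 oxygen; one six-membered non-aromatic ring of carbon only), on a double-bonded chain carbon bound to a double-bonded chain carbon. Only the two measured values exist to anchor an expectation, and compound 2 carries the entering group twice while compound 1 carries it not at all. The step expected in this assay is an at least 1.3-fold lower number from compound 1 to compound 3 (0.13 log units; that floor lies within the scatter), small and within the scatter or slightly toward stronger inhibition. Compound 3 is estimated at 500000 nM, with a range from 250000 nM to 1000000 nM, and a fair chance that this assay again reports only a limit.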

Compound 3, half-maximal inhibitory concentration: 221000 nM
For compound 3 the middle estimate is 2.3-fold (0.35 log units) above the measured one, and the stated range ends above it.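

Changing the group at this position does register: in this assay the group of 8 heavy atoms in place of the group of 9 heavy atoms, on a double-bonded chain carbon bound to a double-bonded chain carbon, gives an at least 3.1-fold lower number from compound 1 to compound 3 (0.49 log units; beyond the scatter). The entering group has 3 double bonds outside aromatic rings against 2 in the leaving group, and 1 hydrogen-bond donor against 2, so a small change in the ring is enough to produce a step beyond the scatter. The size of that step is only a floor, and the real step may be larger, because one end of it is a limit of the assay and not a number: the limit of > 690000 nM in this assay, at which 1 of the 3 values shown sits.

Which of the differences between the two rings carries the step remains open. Also open, on these data alone, is how an amine, a carboxylic acid or a longer chain at this place would read in this assay.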